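The source may hold more compounds than are shown below. What is called first, only, known or untested is meant among the compounds shown, and "the series" means these compounds.

Among the measured compounds shown here, in a functional assay on MGC-803 cells (Homo sapiens) for inhibition, read by MTT assay, with a stated time of 72 h (on this read-out higher numbers stand for weaker inhibition and lower numbers for stronger inhibition), compound 3 `FC(F)(F)c1ccc(CSc2nc(Sc3nncs3)cc(C(F)(F)F)n2)cc1` gives 10900 nM, the lower of the two actual numbers so far. Compound 1 `CCN1CCN(c2cc(C(F)(F)F)nc(SCc3ccc(C(F)(F)F)cc3)n2)CC1` gives 25600 nM, and the change at its 4-ethylpiperazin-1-yl group gives a 2.3-fold lower number from compound 1 to compound 3 (0.37 log units; beyond the scatter). Compound 2 `FC(F)(F)c1ccc(CSc2nc(Sc3ccccn3)cc(C(F)(F)F)n2)cc1` reads > 50000 nM, which is a limit of the assay and not a number. Compound 4 `FC(F)(F)c1ccc(CSc2nc(SC3=NCCS3)cc(C(F)(F)F)n2)cc1` alters only the group on a sulfur: a group of 5 heavy atoms (3 carbon, 1 nitrogen, 1 sulfur; one five-membered non-aromatic ring with 2 hetero atoms) in place of a group of 5 heavy atoms (2 carbon, 2 nitrogen, 1 sulfur; one five-membered aromatic ring with 3 hetero atoms), on a sulfur. For the measured compounds named here, the closest precedent is the other change on that sulfur, an at least 4.5-fold lower number from compound 2 to compound 3 (0.66 log units; beyond the scatter), which shows that losing the 1,3,4-thiadiazol-2-yl group can matter. The expected step in this assay is therefore a 2.2-fold higher number from compound 3 to compound 4 (0.34 log units; beyond the scatter), a modest move towards weaker inhibition. Compound 4 is estimated at 24000 nM, with an expected range from 9000 nM to 60000 nM.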

Compound 4, half-maximal inhibitory concentration: 24500 nM
The estimate for compound 4 lay 1.0-fold (0.01 log units) below the measured number; low and high end bracket the measured number.
By their numbers in this assay, from the lowest: compound 3; then compounds 4 and 1 (each within the scatter of the next). At a limit, above all of these: compound 2.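

Keeping the ring size on the sulfur but replacing the aromatic 1,3,4-thiadiazol-2-yl with the non-aromatic ring weakens inhibition, a 2.2-fold higher number from compound 3 to compound 4 (0.35 log units; beyond the scatter), so not every five-membered ring serves equally here. The step of a 1.0-fold lower number from compound 1 to compound 4 (0.02 log units; within the scatter) leaves this ring level with 4-ethylpiperazin-1-yl on the aromatic carbon. The step of an at least 2.0-fold lower number from compound 2 to compound 4 (0.30 log units; that floor lies within the scatter) is only a floor, and compound 2 reads as a limit, not a number: the limit of > 50000 nM in this assay, at which 1 of the 4 values shown sits.

On these data alone, whether aromaticity itself or the ring's particular atoms set compound 3 apart stays open. A 1,2,4-triazol-3-yl ring or an open chain ending in a carboxylic acid on that sulfur could help separate the two.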